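Capping the Hydroxyl on the Way to Compound 3

The source may hold more compounds than are shown below. What is called first, only, known or untested is meant among the compounds shown, and "the series" means these compounds.

Compound 2 `CO/N=C(/c1ccc(Cl)cc1)C(O)CN1CCN(c2ccccn2)CC1` stands at the lower end of the two numbers available: in a functional assay on HEK293 cells with D(4) dopamine receptor (Homo sapiens) as the target, read by FLIPR (on this read-out higher numbers stand for an effect only at larger amounts of compound and lower numbers for an effect already at smaller amounts), compound 2 gives 22.6 nM, whereas compound 1 `CO/N=C(\c1ccc(Cl)cc1)C(O)CN1CCN(c2ccccn2)CC1` gives 46 nM. Going by the values given here, the single measured step, a 2.0-fold lower number from compound 1 to compound 2 (0.31 log units; beyond the scatter), turns on a differently drawn double bond the fact that one of compounds 1 and 2 is drawn with a defined configuration and the other without, at the place where they differ and has no bearing on the change now considered. Compound 3 `CO/N=C(/c1ccc(Cl)cc1)C(CN1CCN(c2ccccn2)CC1)OC` differs from compound 2 by methyl in place of hydrogen on an oxygen on a saturated carbon, hydroxy to methoxy. Among the compounds with values here, with no measured step to guide it, compound 3 is expected near 30 nM (range 8 nM to 110 nM), an estimated 1.3-fold higher number from compound 2 to compound 3 (0.12 log units; within the scatter) that stays within the scatter.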

Compound 3, half-maximal effective concentration: 285 nM
Compound 3: middle estimate off by 9.5-fold (0.98 log units), on the low side; the whole stated range lies below it.
By their numbers in this assay, from the lowest: compound 2; then compound 1; then compound 3.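

In this assay, methyl in place of hydrogen on an oxygen on a saturated carbon gives a 13-fold higher number from compound 2 to compound 3 (1.10 log units; beyond the scatter), so this oxygen is far from indifferent to capping. Going by these compounds alone, that step outweighs a 2.0-fold lower number from compound 1 to compound 2 (0.31 log units; beyond the scatter), the only change previously seen. Nothing available speaks to why capping this oxygen has so large an effect.

From the compounds shown here alone, whether any cap on this oxygen behaves like methyl remains open, as an ethoxy group or an acetate ester would show. Going by these compounds, it is equally open whether an amine in place of the hydroxy would be tolerated.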